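Changing the Ring Nitrogen Substituent: Expected Maximal Response

The source may hold more compounds than are shown below. What is called first, only, known or untested is meant among the compounds shown, and "the series" means these compounds.

Measured in a functional assay on cells for agonist activity at Glucose-dependent insulinotropic receptor (Homo sapiens), read by a luciferase reporter, with a stated time of 4 h; on this read-out lower numbers stand for smaller maximal responses and higher numbers for larger maximal responses:
compound 1 `CC(=O)c1cnc(N2CCC(c3coc4c(N5CCc6cc(S(C)(=O)=O)ccc65)ncnc34)CC2)nc1`: 12%
compound 2 `CS(=O)(=O)c1ccc2c(c1)CCN2c1ncnc2c(C3CCN(c4ncc(Cl)cn4)CC3)coc12`: 117%
compound 3 `CC(C)(C)OC(=O)N1CCC(c2coc3c(N4CCc5cc(S(C)(=O)=O)ccc54)ncnc23)CC1`: 123%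

Compound 3 stands highest of the three numbers. Compound 2 lies close to it, a number 6 percentage points higher from compound 2 to compound 3 (within the scatter), while compound 1 sits far below, a number 111 percentage points higher from compound 1 to compound 3 (beyond the scatter). Compound 4 `COc1cnc(N2CCC(c3coc4c(N5CCc6cc(S(C)(=O)=O)ccc65)ncnc34)CC2)nc1` has not yet been measured in this assay. It differs from compound 3 in one place: 5-methoxypyrimidin-2-yl in place of tert-butoxycarbonyl on an amine nitrogen in a ring. Going by the values given here, two measured steps bear on this change, and they point in different directions. The step of a number 6 percentage points higher from compound 2 to compound 3 (within the scatter) was within the scatter, whereas a number 111 percentage points higher from compound 1 to compound 3 (beyond the scatter) was large. Among the compounds with values here, a third substituted pyrimidinyl group therefore has no firm precedent, and compound 4 is expected to land between these two outcomes, with a wide range. Compound 4 is estimated at 85%, from 20% to 125%, which would be an expected step of a number 38 percentage points lower from compound 3 to compound 4 (beyond the scatter).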

Compound 4, largest response reached (Emax), in percent of the reference or control that the assay uses: 186%
Beside the measured number, compound 4's estimate is 101 percentage points below it; the whole stated range lies below it.
By their numbers in this assay, from the lowest: compound 1; then compounds 2 and 3 (each within the scatter of the next); then compound 4.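

With the 5-methoxypyrimidin-2-yl group on the amine nitrogen in the ring, this assay shows a number 63 percentage points higher from compound 3 to compound 4 (beyond the scatter), so a pyrimidinyl group at this position can exceed tert-butoxycarbonyl, which neither earlier pyrimidinyl compound did. The group on the aromatic carbon of the pyrimidinyl ring also matters greatly: methoxy in place of chloro gives a number 69 percentage points higher from compound 2 to compound 4 (beyond the scatter), and methoxy in place of acetyl gives a number 174 percentage points higher from compound 1 to compound 4 (beyond the scatter). Nothing available here explains these differences. On these data alone, whether an ethoxy group or an amine on that aromatic carbon would match methoxy or fall towards acetyl remains open.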